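A few compounds are considered here, and "the series" means these few. Any claim that something is new, unique, unknown or untested is made for them only; others in the source may bear on it.

In a functional assay on the whole organism with Mus musculus as the target (on this read-out higher numbers stand for an effect only at larger amounts of compound and lower numbers for an effect already at smaller amounts), three compounds have been measured so far. Compound 1 (`CC(C)NC(=O)/C=C1\CCc2ccc(F)cc21`) gives 96 mg/kg, compound 2 (`O=C(/C=C1\CCc2c(F)cc(F)cc21)NCCO`) gives 100 mg/kg and compound 3 (`CC(C)NC(=O)/C=C1\CCc2c(F)cc(F)cc21`) gives 50 mg/kg. All three numbers lie within the scatter of one another, so compound 1 cannot be separated from either neighbour.

Compound 4 (`NC(=O)/C=C1\CCc2ccc(F)cc21`) differs from compound 1 at a single place, with hydrogen in place of isopropyl on an amide-type nitrogen. Two measured steps are available. The closer one changes the same nitrogen, and a 2.0-fold lower number from compound 2 to compound 3 (0.30 log units; within the scatter) is what it shows for isopropyl in place of 2-hydroxyethyl. The other, a 1.9-fold lower number from compound 1 to compound 3 (0.28 log units; within the scatter), is fluoro in place of hydrogen on an aromatic carbon and says nothing directly about the nitrogen. Both steps stay within the scatter. For the measured compounds named here, no measured compound carries hydrogen on that nitrogen, so the size of this change remains untested, and the series offers no ground for expecting a shift beyond the scatter in this assay. The expected step is a 1.1-fold higher number from compound 1 to compound 4 (0.06 log units; within the scatter), an estimate that leans only slightly upward. For compound 4 the estimated value is 110 mg/kg, with an expected range of 50 mg/kg to 240 mg/kg.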

Compound 4, dose for half-maximal effect: 56 mg/kg
Estimate against measurement, compound 4: 2.0-fold (0.29 log units) above, within the range that was stated.
By their numbers in this assay, from the lowest: compounds 3, 4, 1 and 2 (each within the scatter of the next).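

For the compounds shown here, until now, the only change read on this amide-type nitrogen was between two carbon substituents, isopropyl and 2-hydroxyethyl; here the substituent is removed altogether, and this assay shows a 1.7-fold lower number from compound 1 to compound 4 (0.23 log units; within the scatter). Taking away all three heavy atoms of the isopropyl group and leaving only hydrogen on the nitrogen therefore does not move the number beyond the scatter, so on the core of compound 1 nothing shows that a carbon group on that nitrogen is required for an effect in the mouse at doses of this order. No measured evidence bears on why the result falls this way.

It remains open whether hydrogen in place of isopropyl gives a step of similar size on the core of compound 3, which carries the additional fluoro group; the compounds shown hold this change on the core of compound 1 only. Also open, going by these compounds, is how this assay would read with other groups on the same nitrogen, such as a longer chain like n-hexyl, a benzyl group or a chain ending in an amine.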